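Methyl Ester to Free Acid: Compound 2 to Compound 3

The source may hold more compounds than are shown below. What is called first, only, known or untested is meant among the compounds shown, and "the series" means these compounds.

Two measured compounds share one core and differ only in a substituent on the ketone-bearing ring. Compound 1 `COC(=O)c1c(Nc2ccc(F)cc2)sc(C(=O)c2ccc(OC)cc2)c1C` gives 5.28% in a functional assay, with a stated time of 150 min, tested at 5 ug/mL; on this read-out higher numbers stand for a stronger effect at the one concentration tested and lower numbers for a weaker effect. Compound 2 `COC(=O)c1c(Nc2ccc(F)cc2)sc(C(=O)c2ccc(C)cc2)c1C` is recorded in this assay as "not active" (no number reported), with no figure behind that word. Compound 2 therefore stands at the bottom of what has been measured, and its nearest relative, compound 1, also sits at the low end of the percentage scale, so neither reading points to a strong response within this pair.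

The step to compound 3 `Cc1ccc(C(=O)c2sc(Nc3ccc(F)cc3)c(C(=O)O)c2C)cc1` is a small one at the ester end of the molecule: hydrogen in place of methyl on an oxygen next to a carbonyl group. For the measured compounds named here, no measured pair of this kind exists in the set, so the size of the step cannot be read from data. Given that compound 2 shows nothing and compound 1 very little, the change is expected to leave the read-out within the scatter of the starting point, in no clear direction. Compound 3 is therefore estimated to give about 4% in this assay, in a range from 0% to 15%.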

Compound 3, a percentage reported as activity, at one concentration (the size of the read-out at that concentration, not a potency): "not active" (no number reported)
Nothing numeric was reported for compound 3; no gap can be computed for the estimate.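

In this assay compound 2 and compound 3 are both recorded as "not active" with no number behind the words, so no step can be read between them. No measured evidence bears on this result. The compounds shown leave open what the change from methoxycarbonyl to carboxy does to this read-out in a compound with a measurable response.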